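Replacing the ring amide hydrogen of compound 1

A few compounds are considered here, and "the series" means these few. Any claim that something is new, unique, unknown or untested is made for them only; others in the source may bear on it.

Compound 1 `COc1cc(-c2nc3cc(/C=C4\SC(=O)NC4=O)ccc3[nH]2)cc(OC)c1OC` gives the lowest number in a functional assay on HeLa cells (Homo sapiens) for inhibition, read by MTT assay, with a stated time of 48 h (on this read-out higher numbers stand for weaker inhibition and lower numbers for stronger inhibition), 1670 nM. Compound 2 `COc1ccc(-c2nc3cc(/C=C4\SC(=O)NC4=O)ccc3[nH]2)cc1OC` gives 7830 nM in this assay, and compound 3 `COc1cc(OC)c(-c2nc3cc(/C=C4\SC(=O)NC4=O)ccc3[nH]2)cc1OC` gives 15400 nM. The two measured steps both concern the methoxy pattern on the aromatic ring of the shared core: a 4.7-fold higher number from compound 1 to compound 2 (0.67 log units; beyond the scatter), and a 2.0-fold higher number from compound 2 to compound 3 (0.29 log units; within the scatter). Compound 1 thus stands nearest to compound 2 and furthest from compound 3, with both gaps beyond the scatter.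

Compound 4 `COc1cc(-c2nc3cc(/C=C4\SC(=O)N(CC(=O)N5CCOCC5)C4=O)ccc3[nH]2)cc(OC)c1OC` keeps the three methoxy groups of compound 1 and differs in one place: ((morpholin-4-yl)carbonyl)methyl in place of hydrogen on an amide-type nitrogen in a ring. Among the compounds with values here, neither measured step touches this amide-type nitrogen, so no measured step bears on the change from compound 1 to compound 4, and its direction cannot be read from the series. The expectation is therefore set wide around the value of compound 1. In this assay the number for compound 4 is expected to lie at 3000 nM, within 600 nM to 15000 nM. This estimate means an expected step of a 1.8-fold higher number from compound 1 to compound 4 (0.25 log units; within the scatter), of a size that the scatter of repeated measurements may well cover.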

Compound 4, half-maximal inhibitory concentration: 16300 nM
Compound 4: the middle estimate sits 5.4-fold (0.74 log units) below what was measured, and the stated range ends below it.
By their numbers in this assay, from the lowest: compound 1; then compounds 2, 3 and 4 (each within the scatter of the next, the first and the last beyond it).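

In this assay, the amide-type nitrogen of the five-membered non-aromatic ring with 1 nitrogen and 1 sulfur proves responsive to substitution: ((morpholin-4-yl)carbonyl)methyl in place of hydrogen gives a 9.8-fold higher number from compound 1 to compound 4 (0.99 log units; beyond the scatter) with the three methoxy groups of compound 1 kept. The number in this series therefore depends on more than the methoxy pattern, and at this position the entering group moves it upward, which is the direction of weaker inhibition on this read-out. Nothing available explains this step.

With a single group on this nitrogen, the loss of the amide hydrogen cannot be separated from the contribution of the carbonyl, the morpholine ring or the chain that links them, so a plain methyl, a longer alkyl chain or an acetic acid group at the same place would be needed to tell these apart. From the compounds shown here alone, it also remains open whether ((morpholin-4-yl)carbonyl)methyl gives a step of similar direction and size on the methoxy patterns of compound 2 and compound 3.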